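This account rests on a few compounds, and the source may have more. Where it says the series, first, only, none or still open, it means among the compounds named here.

Three close relatives of one shared core have been tested in a functional assay on HeLa cells (Homo sapiens) for cytotoxicity, read by MTT assay; on this read-out higher numbers stand for weaker inhibition and lower numbers for stronger inhibition. Compound 1 `CC(C)=CC[C@@H](OC(=O)c1ccco1)C1=CC(=O)c2c(O)ccc(O)c2C1=O` gives 80300 nM. Compound 2 `COC(C)CO[C@H](CC=C(C)C)C1=CC(=O)c2c(O)ccc(O)c2C1=O` gives 53400 nM. Compound 3 `CCCCC(CC(=O)O[C@H](CC=C(C)C)C1=CC(=O)c2c(O)ccc(O)c2C1=O)OC(C)=O` gives 73500 nM. Compound 2 sits alongside the other two: its separations from compound 1 and from compound 3 are both within the scatter, so none of the three can be told apart on this read-out.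

Compound 4 `CCCC(C)(O)CC(=O)O[C@H](CC=C(C)C)C1=CC(=O)c2c(O)ccc(O)c2C1=O` has not yet been measured. It differs from compound 2 at a single point ((2-hydroxy-2-methylpentyl)carbonyl in place of 2-methoxypropyl on an oxygen on a saturated carbon). Going by the values given here, two measured steps bear on this change. The step of a 1.5-fold lower number from compound 1 to compound 2 (0.18 log units; within the scatter) exchanged a carbonyl-linked group for a chain-linked group on the same oxygen, and the step of a 1.1-fold lower number from compound 1 to compound 3 (0.04 log units; within the scatter) exchanged one group on a carbonyl carbon for another; both stayed within the scatter. Compound 4 returns to a carbonyl-linked group on that oxygen, so the step of a 1.2-fold higher number from compound 2 to compound 4 (0.06 log units; within the scatter) is expected to be small, with no change beyond the scatter in either direction. Compound 4 is therefore estimated at 62000 nM, with a range from 25000 nM to 150000 nM.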

Compound 4, half-maximal inhibitory concentration: 72000 nM
Compound 4: the middle estimate sits 1.2-fold (0.06 log units) below what was measured; the range from low to high includes it.
By their numbers in this assay, from the lowest: compounds 2, 4, 3 and 1 (each within the scatter of the next).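

On the oxygen on a saturated carbon, (2-hydroxy-2-methylpentyl)carbonyl carries a hydrogen-bond donor where 2-methoxypropyl has none, yet the number in this assay stays within the scatter (a 1.3-fold higher number from compound 2 to compound 4 (0.13 log units; within the scatter)). Among the groups on the carbonyl carbon, a free hydroxyl in place of an acetoxy-bearing chain (a 1.0-fold lower number from compound 3 to compound 4 (0.01 log units; within the scatter)) and an open chain in place of furan-2-yl (a 1.1-fold lower number from compound 1 to compound 4 (0.05 log units; within the scatter)) also leave the number within the scatter, so all four side chains shown here read alike. Nothing available explains this sameness.

From the compounds shown here alone, whether an amine, a carboxylic acid or a much longer chain on this oxygen would move the number beyond the scatter remains open. The free hydroxyl on the shared core's quinone-free side is also not varied in the compounds shown.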